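Acetylated Sugar Analogue with a Thiourea: Vero Cell Toxicity Outlook

This account rests on a few compounds, and the source may have more. Where it says the series, first, only, none or still open, it means among the compounds named here.

Three compounds that share an unsaturated ketone joined to a sugar-derived ring have been measured in an ADME assay on Vero cells (Chlorocebus sabaeus) for cytotoxicity, read by resazurin assay, with a stated time of 2 days; on this read-out lower numbers stand for higher toxicity in this test and higher numbers for lower toxicity in this test. Compound 1 `O=C(/C=C/c1cccc(NC(=S)Nc2ccccc2)c1)C[C@@H]1O[C@H](CO)[C@@H](O)[C@H](O)[C@H]1O` carries a thiourea on the aromatic ring; in this assay compound 1 gives 371000 nM. Compound 2 `Cc1ccc(S(=O)(=O)Nc2cccc(/C=C/C(=O)C[C@@H]3O[C@H](CO)[C@@H](O)[C@H](O)[C@H]3O)c2)cc1` carries a sulfonamide at the same nitrogen; in this assay compound 2 gives 381000 nM. The two are related by a single change, (a group of 9 heavy atoms (7 carbon, 1 nitrogen, 1 sulfur; one six-membered aromatic ring of carbon only) in place of a group of 10 heavy atoms (7 carbon, 2 oxygen, 1 sulfur; one six-membered aromatic ring of carbon only), on a nitrogen on an aromatic ring), and that change made a 1.0-fold lower number from compound 2 to compound 1 (0.01 log units; within the scatter).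

Compound 3 `CC(=O)O[C@@H]1[C@@H](OC(C)=O)[C@H](OC(C)=O)CO[C@H]1CC(=O)/C=C/c1cccc(NS(=O)(=O)c2ccc(C)cc2)c1` keeps the sulfonamide of compound 2 but its sugar part bears acetyl groups in place of free hydroxyls; the difference between the two cores is not broken down here. In this assay compound 3 gives 268000 nM, a value that lies within the usual scatter of both compound 1 and compound 2.

Compound 4 `CC(=O)O[C@@H]1[C@@H](OC(C)=O)[C@H](OC(C)=O)CO[C@H]1CC(=O)/C=C/c1cccc(NC(=S)Nc2ccccc2)c1` is not yet measured in this assay. It stands to compound 3 as compound 1 stands to compound 2: the change is a group of 9 heavy atoms (7 carbon, 1 nitrogen, 1 sulfur; one six-membered aromatic ring of carbon only) in place of a group of 10 heavy atoms (7 carbon, 2 oxygen, 1 sulfur; one six-membered aromatic ring of carbon only), on a nitrogen on an aromatic ring, the same change at the same place. Because a 1.0-fold lower number from compound 2 to compound 1 (0.01 log units; within the scatter) was within the scatter, the step from compound 3 to compound 4 is expected to be a 1.0-fold lower number from compound 3 to compound 4 (0.01 log units; within the scatter). On this basis compound 4 is estimated to give 260000 nM in this assay, with a range from 130000 nM to 520000 nM expected.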

Compound 4, half-maximal cytotoxic concentration: 58700 nM
Estimate against measurement, compound 4: 4.4-fold (0.65 log units) above, outside the stated range (below it).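

In this assay, putting the phenyl thiourea group in place of the (4-methylphenyl)sulfonyl group on the aromatic nitrogen gave a 4.6-fold lower number from compound 3 to compound 4 (0.66 log units; beyond the scatter), so on the acetylated core this change is accompanied by a lower number, which on this read-out stands for higher toxicity in this test. Among these compounds, the change therefore did not carry over from one core to the other with the same size, and a step read on the core of compound 2 would have been a poor guide to the step on the core of compound 3: the same change on two cores in this assay, a 1.0-fold lower number (0.01 log units; within the scatter) from compound 2 to compound 1 and a 4.6-fold lower number (0.66 log units; beyond the scatter) from compound 3 to compound 4, 4.4-fold (0.65 log units) apart, beyond the scatter of two such steps This shows that the outcome of the change depends on the core in these two pairs, but with only one pair on each core it does not show a general rule for the series, nor which feature of the cores is responsible, since they differ in more than one place and that difference is not broken down.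

On these data alone, it remains open whether other groups on the same nitrogen, such as a urea or a simple acetamide, would also give different steps on the two cores. As far as these compounds go, it also remains open whether the acetyl groups alone, or some other part of the core, go with the larger step.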